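Swapping a chloropyridinyl amine for a thiazolyl amine

The source may hold more compounds than are shown below. What is called first, only, known or untested is meant among the compounds shown, and "the series" means these compounds.

Compound 2 `Clc1ncccc1Nc1nnc(-c2ccc(Br)cc2)c2ccccc12` gives 1700 nM in a functional assay on MCF7 cells (Homo sapiens) for antiproliferative activity, read by sulforhodamine B assay, with a stated time of 72 h; on this read-out lower numbers stand for stronger inhibition and higher numbers for weaker inhibition. That places compound 2 level with compound 1 `Clc1cccc(Cl)c1Nc1nnc(-c2ccc(Br)cc2)c2ccccc12`, which gives 1700 nM, the two together sitting lowest of the three measured compounds, while compound 3 `Brc1ccc(-c2nnc(N(Cc3ccccc3)Cc3ccccc3)c3ccccc23)cc1` gives 4800 nM. Within the data shown here, the only measured step of this kind, no change at the digits printed from compound 1 to compound 2 (within the scatter), exchanged one aryl group for another on a nitrogen on an aromatic ring. Compound 4 `Brc1ccc(-c2nnc(Nc3nccs3)c3ccccc23)cc1` carries a further exchange of that sort: 1,3-thiazol-2-yl in place of 2-chloropyridin-3-yl on a nitrogen on an aromatic ring. Among the measured compounds shown here, with the one comparable step flat, no step beyond the scatter is expected in this assay, so compound 4 is estimated at 2000 nM, between 900 nM and 5000 nM, the expected step being a 1.2-fold higher number from compound 2 to compound 4 (0.07 log units; within the scatter).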

Compound 4, half-maximal inhibitory concentration: 1400 nM
Beside the measured number, compound 4's estimate is 1.4-fold (0.15 log units) above it, and the stated range covers the measured number.
By their numbers in this assay, from the lowest: compounds 4, 1 and 2 (each within the scatter of the next); then compound 3.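

In this assay, the step of a 1.2-fold lower number from compound 2 to compound 4 (0.08 log units; within the scatter) and the step of a 1.2-fold lower number from compound 1 to compound 4 (0.08 log units; within the scatter) both lie within the scatter. The flat result seen earlier between two six-membered aromatic rings therefore also holds for a five-membered aromatic ring with 2 hetero atoms and no chlorine on it. The data shown offer nothing that explains this flatness. Still open, from the compounds shown here alone, is whether an aryl group carrying a carboxylic acid or a morpholine on this nitrogen would stay level with these compounds in this assay.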